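Configuration change from compound 1 to compound 3

The source may report more compounds than this note shows. Statements on the series, on what has been measured and on what is new or still open speak of the compounds shown alone.

Measured so far in a physicochemical assay for lipophilicity, at pH 7.4 (a higher number here means a more lipophilic compound, a lower number a more polar compound), for two compounds
- compound 1 `C[C@@H]1[C@@H]2CN(c3nc(Nc4cnn(C)c4)ncc3F)C[C@]12NC(=O)[C@H]1C[C@@H]1C#N` gives 2.32 
- compound 2 `CCNC(=O)c1ccc(Nc2nccc(N3CC4CC(C3)N4C(=O)C3CC3)n2)cc1` gives 1.7 

Compound 1 holds the higher of the two numbers, and compound 2 lies lower by more than the scatter. Compound 3 `C[C@@H]1[C@@H]2CN(c3nc(Nc4cnn(C)c4)ncc3F)C[C@]12NC(=O)[C@@H]1C[C@H]1C#N` is not yet measured. Against compound 1 it shows the two compounds have the same atoms and bonds and differ only in configuration as drawn: 2 of 5 stereo elements differ; a stereocentre at a saturated ring carbon is drawn S in compound 1 and R in compound 3; a stereocentre at a saturated ring carbon is drawn S in compound 1 and R in compound 3 and a stereocentre at a saturated ring carbon is drawn S in compound 1 and R in compound 3, twice over. Among the compounds with values here, no measured pair shows a change of configuration alone. The estimated a number 0.02 log units lower from compound 1 to compound 3 (within the scatter) is expected to stay within the scatter, with no direction favoured. Compound 3 is expected in this assay at 2.3 with an estimated range from 2 to 2.6 as the working figure.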

Compound 3, distribution coefficient: 2.35
For compound 3 the middle estimate is 0.05 log units below the measured one; measured number inside the range.
By their numbers in this assay, from the lowest: compound 2; then compounds 1 and 3 (each within the scatter of the next).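

In this assay the step is a number 0.03 log units higher from compound 1 to compound 3 (within the scatter), so the series now holds a measured pair in which inverting these two stereocentres at saturated ring carbons leaves the two configurations unseparated. The step reads as one of configuration alone: the fact that compounds 1 and 3 differ only in the configuration as drawn.

From the compounds shown here alone, whether this holds for the stereo elements that compound 1 and compound 3 share stays open, as a single pair cannot show it. Also open, going by these compounds, is whether the two configurations would stay within the scatter of each other with an amine or a carboxylic acid on the shared core.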